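A few compounds are considered here, and "the series" means these few. Any claim that something is new, unique, unknown or untested is made for them only; others in the source may bear on it.

Measured compounds in a functional assay on PC-3 cells (Homo sapiens) for inhibition, read by sulforhodamine B assay, with a stated time of 48 h; a higher number here means a weaker inhibitor of growth, a lower number a stronger inhibitor of growth:

Compound 1 `COC1=C[C@H](O)[C@H](C/C=C(\C)CC/C=C(\C)C[C@H](O)/C=C(\C)CO)[C@@H](C)C1=O` gives > 30000 nM, which is a limit of the assay.
Compound 2 `COC1=C(OC)[C@H](O)[C@H](C/C=C(\C)CC/C=C(\C)C/C=C/C(C)(C)O)[C@@H](C)C1=O` gives > 30000 nM, also a limit.
Compound 3 `COC1=C(OC)[C@H](OC(C)=O)[C@H](C/C=C(\C)CC/C=C(\C)C[C@H](O)C[C@@H](C)C(O)O)[C@@H](C)C1=O` gives > 30000 nM, again a limit.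

Compound 3 therefore stands nowhere in particular on the numbers shown: its own result is a limit, and the two further values are limits as well, so the whole set sits at the limit of > 30000 nM in this assay, at which 3 of the 3 values shown sit. Among the measured compounds shown here, each of the three compounds differs from the others in more than one place, so no single step between measured compounds can be counted, and the values only show that none of the three reached a measurable concentration for half-maximal growth inhibition within the tested range.

Compound 4 `COC1=C(OC)[C@H](OC(C)=O)[C@H](C/C=C(\C)CC/C=C(\C)C[C@H](O)/C=C(\C)C(=O)O)[C@@H](C)C1=O` is the next compound for this assay. It differs from compound 3 by a group of 6 heavy atoms (4 carbon, 2 oxygen; no ring) in place of a group of 6 heavy atoms (4 carbon, 2 oxygen; no ring), on a saturated chain carbon bound to an oxygen on a saturated carbon and a saturated chain carbon. Since every known value is a limit, no size or direction of a step can be read from the data, and the change is expected to produce none beyond the scatter: the estimated step of a number no higher from compound 3 to compound 4 (the limit leaves the size open) keeps compound 4 at the limit. Compound 4 is accordingly expected to give about 30000 nM, within a range of 10000 nM to 100000 nM.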

Compound 4, concentration for 50% growth inhibition: > 30000 nM
Compound 4 gave a limit, no number (the forecaster's own chance of this, stated with the estimate: 70%); the middle value lies on the limit itself.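

The results for compound 3 and compound 4 are both limits, so no size or direction of a step can be read between them. The compounds shown leave open which structural change, if any, would bring growth inhibition to a measurable concentration, as all of them share one result: the limit of > 30000 nM in this assay, at which 4 of the 4 values shown sit.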